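Removing the indole benzyl group from a thiazolyl semicarbazone

This account rests on a few compounds, and the source may have more. Where it says the series, first, only, none or still open, it means among the compounds named here.

In a functional assay on NCI-H460 cells (Homo sapiens) for cytotoxicity, read by MTT assay, with a stated time of 72 h (on this read-out lower numbers stand for stronger inhibition and higher numbers for weaker inhibition), compound 2 `CCN(CC)Cc1ccc2nc(NC(=O)N/N=C/c3cn(Cc4ccc(Cl)cc4Cl)c4ccccc34)sc2c1` gives 1080 nM, the second highest of the three numbers measured. Its nearest neighbour is compound 1 `CC1CCN(Cc2ccc3nc(NC(=O)N/N=C/c4cn(Cc5ccc(Cl)cc5Cl)c5ccccc45)sc3c2)CC1`, which gives 1660 nM; the step of a 1.5-fold lower number from compound 1 to compound 2 (0.19 log units; within the scatter) lies within the scatter. Among the compounds with values here, compound 3 `Cc1ccc(Cn2cc(/C=N/NC(=O)Nc3nc4ccc(CN5CCC(C)CC5)cc4s3)c3ccccc32)cc1` gives 410 nM, and the step of a 4.0-fold lower number from compound 1 to compound 3 (0.61 log units; beyond the scatter) is the only change beyond the scatter seen so far.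

Compound 4 `CCN(CC)Cc1ccc2nc(NC(=O)N/N=C/c3c[nH]c4ccccc34)sc2c1` differs from compound 2 by hydrogen in place of 2,4-dichlorobenzyl on an aromatic nitrogen. Within the data shown here, no measured step removes this group altogether: the step from compound 1 to compound 3 only exchanged 2,4-dichlorophenyl for 4-methylphenyl while keeping the benzyl in place, so it bears on the present change only loosely. The data therefore give no firm guide, and a loss of the whole 2,4-dichlorobenzyl is a much larger change than any measured here. For compound 4 a weaker result is expected, with the step of a 3.2-fold higher number from compound 2 to compound 4 (0.51 log units; beyond the scatter) taken as the estimate. Compound 4 is estimated at 3500 nM, within a range of 900 nM to 14000 nM.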

Compound 4, half-maximal inhibitory concentration: 3140 nM
Compound 4: middle estimate off by 1.1-fold (0.05 log units), on the high side; measured number inside the range.
By their numbers in this assay, from the lowest: compound 3; then compounds 2, 1 and 4 (each within the scatter of the next, the first and the last beyond it).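

Within the data shown here, this is the first step that takes the whole 2,4-dichlorobenzyl off the aromatic nitrogen, leaving hydrogen, and it is a 2.9-fold higher number from compound 2 to compound 4 (0.46 log units; beyond the scatter) for that loss. The group therefore contributes to the result in this series, yet its 9 heavy atoms are not indispensable, since compound 4 still gives a measured 3140 nM without them. Nothing at hand explains the size of this step.

The compounds shown leave open whether a plain benzyl, a methyl or a 2-aminoethyl chain on that nitrogen would give a number closer to compound 2 or to compound 4. They also leave open whether the same removal would cost as much with 4-methylpiperidin-1-yl in place of diethylamino, or from the 4-methylbenzyl of compound 3.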